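Working notes: the step from compound 2 to compound 3

This account rests on a few compounds, and the source may have more. Where it says the series, first, only, none or still open, it means among the compounds named here.

Measured in an ADME assay on CEM-SS cells (Homo sapiens) for cytotoxicity, read by XTT assay; on this read-out lower numbers stand for higher toxicity in this test and higher numbers for lower toxicity in this test:
- compound 1 `CN(O)C(=O)c1cc2c(CN3CCNC(=O)C3)cn(Cc3ccc(F)cc3)c2cn1`: > 100000 nM (a limit)
- compound 2 `CN(O)C(=O)c1cc2c(COC3CCOCC3)cn(Cc3ccc(F)cc3)c2cn1`: > 100000 nM (a limit)

Compound 2 gives no number, only the limit > 100000 nM. Compound 3 `CN(O)C(=O)c1cc2c(C(=O)N3CCC[C@@H]3CO)cn(Cc3ccc(F)cc3)c2cn1` carries (2-(hydroxymethyl)pyrrolidin-1-yl)carbonyl in place of ((oxan-4-yl)oxy)methyl on an aromatic carbon, with (2-(hydroxymethyl)pyrrolidin-1-yl)carbonyl in place of ((oxan-4-yl)oxy)methyl on an aromatic carbon. Within the data shown here, the one measured step bearing on this, a step that the two limits leave unreadable from compound 1 to compound 2, offers no size to carry over, and the series shows only (the limit of > 100000 nM in this assay, at which 2 of the 2 values shown sit). In this assay no change beyond the scatter is therefore expected for a number no higher from compound 2 to compound 3 (the limit leaves the size open). The estimated value for compound 3 is 100000 nM, with an expected range of 40000 nM to 200000 nM.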

Compound 3, half-maximal cytotoxic concentration: > 32000 nM
Compound 3: no number, only a limit (the forecaster's own chance of this, stated with the estimate: 85%); the middle value is on the limit's open side.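

In this assay, among these compounds, compound 1, compound 2 and compound 3 each give only a limit, and no step among them can be read. The compounds shown leave open whether their cytotoxicity differs at all, and at what concentration each would reach its half-maximal effect.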